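A few compounds are considered here, and "the series" means these few. Any claim that something is new, unique, unknown or untested is made for them only; others in the source may bear on it.

Measured compounds:

Compound 1, `CCCCCCC(=O)Nc1ccn([C@@H]2CO[C@H](CO)O2)c(=O)n1`, 1040 nM
Compound 2, `CCCCCCCCC(=O)Nc1ccn([C@@H]2CO[C@H](CO)O2)c(=O)n1`, 46 nM
Compound 3, `CCCCCCCCCCCCCCCCCC(=O)Nc1ccn([C@@H]2CO[C@H](CO)O2)c(=O)n1`, 25 nM

All three compounds share one core and differ only in the length of the saturated chain attached through an amide to that core. They were tested in a functional assay on A549 cells (Homo sapiens) for cytotoxicity, read by sulforhodamine B assay, with a stated time of 72 h; on this read-out higher numbers stand for weaker inhibition and lower numbers for stronger inhibition. Compound 1, with the shortest chain, gives 1040 nM. Compound 2 carries ethyl in place of hydrogen on a saturated chain carbon, six bonds along the chain from a carbonyl carbon, and this change produces a 23-fold lower number from compound 1 to compound 2 (1.35 log units; beyond the scatter). Compound 3 carries, relative to compound 1, (undecyl in place of hydrogen on a saturated chain carbon, six bonds along the chain from a carbonyl carbon), giving a 42-fold lower number from compound 1 to compound 3 (1.62 log units; beyond the scatter). Between the two longer chains the gain is far smaller: the step is a 1.8-fold lower number from compound 2 to compound 3 (0.26 log units; within the scatter), so compound 2 and compound 3 cannot be told apart on this read-out.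

The untested compound 4, `CCCCCCCCCCCCCCCCCCCC(=O)Nc1ccn([C@@H]2CO[C@H](CO)O2)c(=O)n1`, extends the chain of compound 3 by ethyl in place of hydrogen on a saturated chain carbon, ten or more bonds along the chain from a carbonyl carbon. This is the same kind of change as that from compound 1 to compound 2, though the place on the chain differs, as the two differences just described show. The first such step was large, but it started from a short chain, and the later lengthening from compound 2 to compound 3 stayed within the usual scatter. The expected step for compound 4 is therefore small, roughly a 1.1-fold lower number from compound 3 to compound 4 (0.06 log units; within the scatter). Compound 4 is expected to give about 22 nM, most likely between 9 nM and 55 nM.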

Compound 4, half-maximal inhibitory concentration: 30 nM
For compound 4 the middle estimate is 1.4-fold (0.13 log units) below the measured one, and the stated range covers the measured number.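

In this assay, the new steps are a 1.2-fold higher number from compound 3 to compound 4 (0.08 log units; within the scatter) and a 1.5-fold lower number from compound 2 to compound 4 (0.19 log units; within the scatter), so lengthening an already long chain gives no change that can be told from the scatter. The same ethyl change therefore does not carry over at a fixed size from the short chain of compound 1 to the long chain of compound 3, though the place on the chain also differs between these two cases: the same change on two cores in this assay, a 23-fold lower number (1.35 log units; beyond the scatter) from compound 1 to compound 2 and a 1.2-fold higher number (0.08 log units; within the scatter) from compound 3 to compound 4, 27-fold (1.43 log units) apart, beyond the scatter of two such steps The undecyl change likewise does not carry over, and these numbers show only that its size depends on the chain it starts from, not why it does: the same change on two cores in this assay, a 42-fold lower number (1.62 log units; beyond the scatter) from compound 1 to compound 3 and a 1.5-fold lower number (0.19 log units; within the scatter) from compound 2 to compound 4, 27-fold (1.43 log units) apart, beyond the scatter of two such steps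

The compounds shown leave open how the large step from compound 1 to compound 2 is spread over the chain, since no chain of intermediate length appears among them, and whether a chain longer than that of compound 4 would stay level. They also leave open whether a chain ending in an amine or a carboxylic acid would fit this pattern, and whether the pattern holds in any other cell line.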